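Swapping the amide ring: pyrazinyl in place of methoxypyridinyl

The source may hold more compounds than are shown below. What is called first, only, known or untested is meant among the compounds shown, and "the series" means these compounds.

Of the compounds shown here, three with a shared core have been measured in a functional assay on NCI-H1975 cells (Homo sapiens) for antiproliferative activity, read by MTT assay, with a stated time of 72 h; a lower number here means a stronger inhibitor, a higher number a weaker inhibitor. Compound 3 `COc1cc(N(C)CCN(C)C)c(NC(=O)c2ccncc2OC)cc1Nc1nccc(-c2cn(C)c3ccccc23)n1` gives 1010 nM, the lowest of the three numbers. Among the compounds with values here, compound 2 `COc1cc(N(C)CCN(C)C)c(NC(=O)c2ccncc2)cc1Nc1nccc(-c2cn(C)c3ccccc23)n1` gives 6860 nM, and the only change between them, a 6.8-fold lower number from compound 2 to compound 3 (0.83 log units; beyond the scatter), shows the methoxy group carries real weight. Within the data shown here, compound 1 `COc1cc(F)c(NC(=O)c2cnccn2)cc1Nc1nccc(-c2cn(C)c3ccccc23)n1` gives 24800 nM, the highest of the three; it differs from compound 3 in more than one place, so no single step links them.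

Compound 4 `COc1cc(N(C)CCN(C)C)c(NC(=O)c2cnccn2)cc1Nc1nccc(-c2cn(C)c3ccccc23)n1` is not yet measured. The change from compound 3 is pyrazin-2-yl in place of 3-methoxypyridin-4-yl on a carbonyl carbon. Among the measured compounds shown here, no measured step covers this exact swap. The closest guide is the methoxy step, since compound 4 also lacks that group; compound 1 carries the same pyrazinyl amide but has fluorine where compounds 2, 3 and 4 carry the amine chain, so its value only shows that the pyrazinyl amide can sit in a weak compound. The expected outcome is a step in the weakening direction, a 4.0-fold higher number from compound 3 to compound 4 (0.60 log units; beyond the scatter), roughly the size of the methoxy step reversed. Compound 4 is therefore estimated at 4000 nM in this assay, with a range from 1000 nM to 16000 nM.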

Compound 4, half-maximal inhibitory concentration: 1220 nM
Compound 4: the middle estimate sits 3.3-fold (0.52 log units) above what was measured; the measured number falls inside the stated range.
By their numbers in this assay, from the lowest: compounds 3 and 4 (each within the scatter of the next); then compound 2; then compound 1.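

In this assay, pyrazin-2-yl in place of 3-methoxypyridin-4-yl on the carbonyl carbon gives a 1.2-fold higher number from compound 3 to compound 4 (0.08 log units; within the scatter), so these two rings cannot be told apart at this position. Pyrazin-2-yl in place of pyridin-4-yl gives a 5.6-fold lower number from compound 2 to compound 4 (0.75 log units; beyond the scatter), which shows that the methoxy group is not the only change to this ring that moves the number away from that of compound 2: a ring with no methoxy group but with 2 hetero atoms reaches the same level as compound 3. With the pyrazinyl amide held constant, (2-(dimethylamino)ethyl)(methyl)amino in place of fluoro gives a 20-fold lower number from compound 1 to compound 4 (1.31 log units; beyond the scatter), so the high number of compound 1 goes with the fluoro group and cannot be blamed on its pyrazinyl amide.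

Nothing shown here offers a reason for any of these steps. On these data alone, it remains open whether a methoxy group on the pyrazin-2-yl ring would add to the effect of the ring swap, and how a plain phenyl ring at the amide, or a morpholine in place of the amine chain, would read in this assay.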